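Cyclopropyl for Ethyl on the Amino Side Chain

A few compounds are considered here, and "the series" means these few. Any claim that something is new, unique, unknown or untested is made for them only; others in the source may bear on it.

Measured compounds:
Compound 1, `CCOc1ccccc1-c1ccc(-c2nc3cnccc3c(N[C@H](CC)C(N)=O)c2C#N)cc1`, gives 3.
Compound 2, `CC[C@@H](Nc1c(C#N)c(-c2ccc(-c3ncccc3C)cc2)nc2cnccc12)C(N)=O`, gives 2.
Compound 3, `CC[C@@H](Nc1c(C#N)c(-c2ccc(-c3ccccc3CO)cc2)nc2cnccc12)C(N)=O`, gives 2.1.

All three numbers come from a physicochemical assay for lipophilicity, read by HPLC, at pH 7.5; a lower number here means a more polar compound, a higher number a more lipophilic compound. Compound 1 stands highest of the three: the nearest is compound 3, a number 0.90 log units lower from compound 1 to compound 3 (beyond the scatter), and the furthest is compound 2, a number 1.00 log units lower from compound 1 to compound 2 (beyond the scatter). Between compound 2 and compound 3 the step is a number 0.10 log units higher from compound 2 to compound 3 (within the scatter), so those two cannot be ordered.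

The unmeasured compound 4, `CCOc1ccccc1-c1ccc(-c2nc3cnccc3c(NC(C(N)=O)C3CC3)c2C#N)cc1`, keeps the biaryl end of compound 1 unchanged and differs only at the amino side chain: a group of 7 heavy atoms (5 carbon, 1 nitrogen, 1 oxygen; one three-membered non-aromatic ring of carbon only) in place of a group of 6 heavy atoms (4 carbon, 1 nitrogen, 1 oxygen; no ring), on a nitrogen on an aromatic ring. None of the three measured steps touches this part of the molecule; all of them alter the aromatic substituent at the far end, so they offer no direct guide to the size of the present step. What remains is the counted change itself: one more carbon atom enters, arranged as a three-membered ring, while the donor and acceptor count stays the same. On that basis a small rise, close to the scatter, is the most that seems warranted.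

Compound 4 is therefore expected to give about 3.2, between 2.8 and 3.6. The expected step is a number 0.20 log units higher from compound 1 to compound 4 (within the scatter), which is an estimate, not a measurement.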

Compound 4, distribution coefficient: 3
Beside the measured number, compound 4's estimate is 0.20 log units above it; the range from low to high includes it.
By their numbers in this assay, from the lowest: compounds 2 and 3 (each within the scatter of the next); then compounds 1 and 4 (each within the scatter of the next).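

In this assay, within the data shown here, replacing the 1-carbamoylpropyl group on the nitrogen with the group carrying a three-membered carbon ring gives no change at the digits printed from compound 1 to compound 4 (within the scatter), the first reading at this position. The earlier steps shown here all altered the 2-ethoxyphenyl group or its ethoxy substituent, and those that moved the number beyond the scatter, such as a number 1.00 log units lower from compound 1 to compound 2 (beyond the scatter), say nothing about the amino side chain; here, one more carbon atom arranged as a ring, with the hydrogen-bond donor and acceptor counts unchanged, produces no difference that can be told from the scatter. No measured evidence bears on why this exchange behaves as it does.

This is one exchange on one background, and compound 4 carries no defined stereocentre in the entering group whereas compound 1 does, so any separate contribution of stereochemistry remains unresolved. Going by these compounds, it remains open whether a cyclobutyl ring or a longer chain such as pentyl in this side chain would also stay within the scatter of compound 1, and whether the same exchange would do so on the 3-methylpyridin-2-yl group of compound 2.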